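The source may report more compounds than this note shows. Statements on the series, on what has been measured and on what is new or still open speak of the compounds shown alone.

Working notes on the series. In a functional assay on PC-3 cells (Homo sapiens), read by MTT assay, with a stated time of 48 h (a lower number here means a stronger inhibitor, a higher number a weaker inhibitor), compound 1 (`CCN(CC)CCNC(=O)c1ccc(C(CC)(CC)c2ccc(OCC(=O)C(C)(C)C)c(C)c2)n1CC`) gives 30 nM and compound 2 (`CCN(CC)CCNC(=O)c1ccc(C(CC)(CC)c2ccc(OCC(O)C(C)(C)C)c(C)c2)n1CC`) gives 220 nM, so compound 2 holds the higher of the two numbers and is the weaker inhibitor of the pair.

Compound 3 (`CCn1c(C(=O)NCC(OC)OC)ccc1C(CC)(CC)c1ccc(OCC(O)C(C)(C)C)c(C)c1`) departs from compound 2 in one place: dimethoxymethyl in place of (diethylamino)methyl on a saturated chain carbon bound to an amide-type nitrogen. This puts dimethoxymethyl in place of (diethylamino)methyl on a saturated chain carbon bound to an amide-type nitrogen, while the rest of compound 2 stays as it is.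

Within the data shown here, only one measured step is available, a 7.3-fold higher number from compound 1 to compound 2 (0.87 log units; beyond the scatter). It replaces (tert-butyl)carbonyl with 1-hydroxy-2,2-dimethylpropyl, which is a different place from the one changed here. Among the measured compounds shown here, no measured pair varies the (diethylamino)methyl group, so that step offers only a rough scale for a single change in this assay, and the direction remains a judgement.

A rise of modest size, of the same order as that step or smaller, seems the likeliest outcome, with wide uncertainty. The expected step is a 3.2-fold higher number from compound 2 to compound 3 (0.50 log units; beyond the scatter). For compound 3 the estimate is 700 nM, with an expected range of 150 nM to 4000 nM.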

Compound 3, half-maximal inhibitory concentration: 14600 nM
Compound 3: middle estimate off by 21-fold (1.32 log units), on the low side, outside the stated range (above it).
By their numbers in this assay, from the lowest: compound 1; then compound 2; then compound 3.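

In this assay, exchanging (2-(diethylamino)ethyl)carbamoyl for (2,2-dimethoxyethyl)carbamoyl gives a 66-fold higher number from compound 2 to compound 3 (1.82 log units; beyond the scatter), the first measured sign that activity in this series depends strongly on the group on the saturated chain carbon bound to an amide-type nitrogen. This step is clearly larger than a 7.3-fold higher number from compound 1 to compound 2 (0.87 log units; beyond the scatter), so of the two single changes shown, the one replacing (diethylamino)methyl with dimethoxymethyl has the greater effect on the number, although only one example of each change is available. The swap removes a group of 5 carbons and 1 nitrogen and introduces one of 3 carbons and 2 oxygens, but no measurement on hand accounts for the size of the step.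

The compounds shown leave open whether the loss follows from losing the diethylamino group or from introducing the two methoxy groups; a plain butyl chain, a 2-(dimethylamino)ethyl chain or a 2-(morpholin-4-yl)ethyl chain at the same place would help separate these. On these data alone, it also remains open whether the same exchange would have a step of similar size on the ketone of compound 1, where the (tert-butyl)carbonyl group is retained.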